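Moving the thiophene link on compound 1

A few compounds are considered here, and "the series" means these few. Any claim that something is new, unique, unknown or untested is made for them only; others in the source may bear on it.

In a functional assay on HL-60 cells (Homo sapiens) for antiproliferative activity, read by MTT assay, with a stated time of 72 h (on this read-out lower numbers stand for stronger inhibition and higher numbers for weaker inhibition), compound 1 (`C=C(Br)C(=O)Nc1ccc2c(c1)/C(=C/c1cccs1)C(=O)N2`) gives 230 nM as the middle of three numbers. Compound 2 (`C=C(Br)C(=O)Nc1ccc2c(c1)/C(=C\c1cccs1)C(=O)N2`) gives 15 nM on its lower side, and compound 3 (`C#CC(=O)Nc1ccc2c(c1)/C(=C/c1ccc[nH]1)C(=O)N2`) gives 5800 nM on its higher side. Compound 4 (`C=C(Br)C(=O)Nc1ccc2c(c1)/C(=C/c1ccsc1)C(=O)N2`) is still unmeasured and differs from compound 1 as follows: thiophen-3-yl in place of thiophen-2-yl on a double-bonded chain carbon bound to a double-bonded ring carbon in words, thiophen-3-yl in place of thiophen-2-yl on a double-bonded chain carbon bound to a double-bonded ring carbon. Within the data shown here, the one measured step runs a 15-fold lower number from compound 1 to compound 2 (1.19 log units; beyond the scatter) and is large, yet it comes with the fact that compounds 1 and 2 differ only in the configuration as drawn and involves no thiophene swap. With no measured swap of this kind, no shift beyond the scatter is expected in this assay and the expected move is a 1.2-fold lower number from compound 1 to compound 4 (0.06 log units; within the scatter) in size. Compound 4 is estimated at 200 nM with 60 nM to 700 nM as the expected range.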

Compound 4, half-maximal inhibitory concentration: 350 nM
Compound 4: middle estimate off by 1.8-fold (0.24 log units), on the low side; the range from low to high includes it.
By their numbers in this assay, from the lowest: compound 2; then compounds 1 and 4 (each within the scatter of the next); then compound 3.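

The swap of thiophen-2-yl for thiophen-3-yl gives a 1.5-fold higher number from compound 1 to compound 4 (0.18 log units; within the scatter) in this assay, so moving the link on this ring leaves the number within the scatter. The earlier step changed only the drawn configuration of the double bond, whereas this pair tests the ring's point of attachment directly. Nothing measured here gives a reason for this result.

Going by these compounds, what a phenyl ring, or a thiophene carrying an amine or a carboxylic acid, would do in this place remains open. So does whether thiophen-3-yl gives a similar number with the double bond drawn E.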